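The source may report more compounds than this note shows. Statements on the series, on what has been measured and on what is new or still open speak of the compounds shown alone.

Measured so far:
Compound 1 `CN1CCN(C/C=C/C(=O)Nc2ccccc2)CC1`: > 8.53 h in an ADME assay for pharmacokinetics, read by LC-MS, in phosphate buffer, with a stated time of 120 min, at pH 7.4, tested at 1 uM, in the presence of a further agent that is not named here; on this read-out higher numbers stand for a longer-lived compound and lower numbers for a shorter-lived compound
Compound 2 `O=C(/C=C/CF)Nc1ccccc1`: > 8.53 h

Compound 2 gives only a limit of the assay, not a number. Compound 1 likewise gives only a limit. Both values sit at the limit of > 8.53 h in this assay, at which 2 of the 2 values shown sit, so no order between them can be read. Compound 3 `CN(C)C/C=C/C(=O)Nc1ccccc1` differs from compound 2 by dimethylamino in place of fluoro on a saturated chain carbon bound to a double-bonded chain carbon. For the measured compounds named here, with no measured step to guide the size, compound 3 is expected to show no change beyond the scatter, landing at the same limit where compound 1 with its own basic amine already sits. The expected step that the limit leaves unreadable from compound 2 to compound 3 is estimated as essentially flat, giving compound 3 an estimated 10 h, with a range from 4 h to 25 h.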

Compound 3, half-life: 1.93 h
Compound 3: the middle estimate sits 5.2-fold (0.71 log units) above what was measured; the whole stated range lies above it.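

On a saturated chain carbon bound to a double-bonded chain carbon, the choice of group does matter in this assay: dimethylamino in place of fluoro gives an at least 4.4-fold lower number from compound 2 to compound 3 (0.64 log units; beyond the scatter). That size is only a floor, as compound 2 gives a limit and not a number: the limit of > 8.53 h in this assay, at which 2 of the 3 values shown sit. Compound 1 carries a different amine at this place and also gives only a limit, > 8.53 h, so an amine there does not settle the outcome alone.

As far as these compounds go, how a primary amine or a methoxy group would behave at this place remains open. So does the effect of a longer chain carrying the dimethylamino group.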